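Urea Variants on a Shared Core: Expectation for Compound 4

The compounds below may be only part of what the source reports. "The series", "measured", "known", "first", "only" and "open" are said of these compounds alone.

Of the compounds shown here, three built on one shared core have been measured in a functional assay on HCT-15 cells (Homo sapiens) for inhibition, read by sulforhodamine B assay, with a stated time of 48 h, tested at 10 uM; on this read-out lower numbers stand for a stronger effect and higher numbers for a weaker effect at the one concentration tested. Compound 1 `COc1cc(Cl)cc(-c2nn(-c3cccc(NC(=O)c4ccc(Cl)c(Cl)c4)c3)cc2-c2ccncc2)c1` carries an amide and gives 57.9%. Compound 2 `COc1cc(Cl)cc(-c2nn(-c3cccc(NC(=O)Nc4ccc(Cl)c(C(F)(F)F)c4)c3)cc2-c2ccncc2)c1` carries a urea and gives 7.28%, while compound 3 `COc1cc(Cl)cc(-c2nn(-c3cccc(NC(=O)Nc4ccc(Cl)c(Cl)c4)c3)cc2-c2ccncc2)c1`, also a urea, gives 13.9%. Compound 3 stands second highest of the three numbers: its nearest neighbour is compound 2, and the step of a number 6.6 percentage points higher from compound 2 to compound 3 (within the scatter) lies within the scatter, whereas the step of a number 44 percentage points lower from compound 1 to compound 3 (beyond the scatter) is large. The step of a number 50.6 percentage points lower from compound 1 to compound 2 (beyond the scatter) is of the same large kind.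

Compound 4 `COc1cc(Cl)cc(-c2nn(-c3cccc(NC(=O)Nc4cccc(C(F)(F)F)c4)c3)cc2-c2ccncc2)c1` has not yet been measured. It differs from compound 3 in one place: 3-(trifluoromethyl)phenyl in place of 3,4-dichlorophenyl on an amide-type nitrogen. Among the measured compounds shown here, the only measured step that concerns a change within the group on the amide-type nitrogen is a number 6.6 percentage points higher from compound 2 to compound 3 (within the scatter), which stayed within the scatter; the two large steps concern the change from amide to urea, and compound 4 keeps the urea. For the measured compounds named here, no measured step covers the change from 3,4-dichlorophenyl to 3-(trifluoromethyl)phenyl, so the direction is open. The expected step is therefore a number 6.1 percentage points higher from compound 3 to compound 4 (within the scatter), small and uncertain. Compound 4 is estimated at 20%, with a range from 5% to 50%.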

Compound 4, a percentage reported as activity, at one concentration (the size of the read-out at that concentration, not a potency): 7.83%
For compound 4 the middle estimate is 12.2 percentage points above the measured one; low and high end bracket the measured number.
By their numbers in this assay, from the lowest: compounds 2, 4 and 3 (each within the scatter of the next); then compound 1.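

At the amide-type nitrogen, 3-(trifluoromethyl)phenyl can stand in place of 3,4-dichlorophenyl in this assay with a number 6.1 percentage points lower from compound 3 to compound 4 (within the scatter) and, seen from the other urea, hydrogen can stand in place of chloro with a number 0.6 percentage points higher from compound 2 to compound 4 (within the scatter). The chloro that the other two ureas both carry on this ring is thus not needed to keep the reading of these ureas. All three ureas now lie within the scatter of one another, and the amide-to-urea contrast holds for a urea without chlorine on this ring as well, with a number 50.1 percentage points lower from compound 1 to compound 4 (beyond the scatter) as a third large step alongside the two already seen from compound 1. Nothing among the available data explains why these exchanges leave the reading in place while the amide stands apart.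

The compounds shown leave open how far this tolerance extends, since every group at this place so far is a halogen-bearing phenyl, and a carboxylic acid, an amine or a nitrile on that ring, or a longer chain in place of the phenyl, could behave differently. With readings at one concentration in one cell line, they also cannot separate the three ureas by potency.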